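From ethyl to bromo: the step to compound 4

This account rests on a few compounds, and the source may have more. Where it says the series, first, only, none or still open, it means among the compounds named here.

Among the measured compounds shown here, in a functional assay on CCRF-CEM cells (Homo sapiens) for antiproliferative activity, read by sulforhodamine B assay, with a stated time of 48 h (a higher number here means a weaker inhibitor, a lower number a stronger inhibitor), compound 1 (`Cc1cccc(NS(=O)(=O)c2ccc(N3CCNC3=O)cc2)c1`) gives 200 nM and compound 2 (`CCc1cccc(NS(=O)(=O)c2ccc(N3CCNC3=O)cc2)c1`) gives 200 nM, so the two stand level at the high end of the three numbers known. Compound 3 (`COc1cc(NS(=O)(=O)c2ccc(N3CCNC3=O)cc2)cc(OC)c1OC`) reads 23 nM, a gap from compound 2 that lies beyond the scatter.

The next compound, compound 4 (`O=C1NCCN1c1ccc(S(=O)(=O)Nc2cccc(Br)c2)cc1`), departs from compound 2 by a single change: bromo in place of ethyl on an aromatic carbon.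

For the measured compounds named here, only one measured step bears on this group: no change at the digits printed from compound 1 to compound 2 (within the scatter), where methyl takes the place of hydrogen on a saturated chain carbon bound to an aromatic carbon. Going by the values given here, no bromo compound has been measured, so this evidence is thin, and compound 3 offers no single-change comparison. No step beyond the scatter is therefore expected in this assay. The expected step is a 1.1-fold lower number from compound 2 to compound 4 (0.05 log units; within the scatter). Compound 4 is estimated at 180 nM, with an expected range of 70 nM to 450 nM.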

Compound 4, half-maximal inhibitory concentration: 110 nM
For compound 4 the middle estimate is 1.6-fold (0.21 log units) above the measured one; low and high end bracket the measured number.
By their numbers in this assay, from the lowest: compound 3; then compounds 4, 1 and 2 (each within the scatter of the next).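

Until now this position had carried only methyl and ethyl. In this assay, bromo can take their place, with a 1.8-fold lower number from compound 2 to compound 4 (0.26 log units; within the scatter) and a 1.8-fold lower number from compound 1 to compound 4 (0.26 log units; within the scatter), so the result extends the tolerated groups at this carbon beyond saturated carbon chains without a step beyond the scatter. Nothing available explains why these three groups read alike.

The compounds shown leave open whether the same holds for a different kind of group at this place meta to a large group, such as an amine, a nitrile or a carboxylic acid. On these data alone, it also remains open whether bromo would read the same on another carbon of this ring, as the single-change comparisons here cover 3-ethylphenyl and 3-bromophenyl and their methyl counterpart alone.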